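A few compounds are considered here, and "the series" means these few. Any claim that something is new, unique, unknown or untested is made for them only; others in the source may bear on it.

Compound 1 `CC(C)c1ccc(-c2nc(SCc3cn(CC(=O)NC(=O)Nc4ccccn4)nn3)nc(Nc3cccc(Cl)c3)c2C#N)cc1` and compound 2 `CC(C)c1ccc(-c2nc(SCc3cn(CC(=O)NC(=O)Nc4ccccn4)nn3)nc(Nc3cccc([N+](=O)[O-])c3)c2C#N)cc1` share one core and differ in a single ring. In a functional assay on MCF7 cells (Homo sapiens) for inhibition, read by MTT assay, with a stated time of 72 h (a lower number here means a stronger inhibitor, a higher number a weaker inhibitor), compound 1 gives 18000 nM, and compound 2 gives 25900 nM; the step of a 1.4-fold higher number from compound 1 to compound 2 (0.16 log units; within the scatter) lies within the scatter, so compound 2 has the higher of the two numbers shown only nominally. Compound 3 `CC(C)c1ccc(-c2nc(SCc3cn(CC(=O)NC(=O)Nc4ccccn4)nn3)nc(Nc3ccccc3F)c2C#N)cc1` differs from compound 2 by 2-fluorophenyl in place of 3-nitrophenyl on a nitrogen on an aromatic ring. Going by the values given here, no measured step swaps exactly these groups; the only step touching this ring, a 1.4-fold higher number from compound 1 to compound 2 (0.16 log units; within the scatter), stayed within the scatter. The expected step is therefore a 1.3-fold lower number from compound 2 to compound 3 (0.11 log units; within the scatter), nothing beyond the scatter. Compound 3 is estimated at 20000 nM in this assay, ranging from 7000 nM to 55000 nM.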

Compound 3, half-maximal inhibitory concentration: > 64000 nM
Compound 3: no number, only a limit; the forecaster's own chance of this, stated with the estimate: 10%; at least 3.2-fold (0.50 log units) between middle value and limit.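

In this assay compound 3 gives only a limit, not a number: the limit of > 64000 nM in this assay, at which 1 of the 3 values shown sits.

Going by these compounds alone, the group on this nitrogen can matter, as the swap to 2-fluorophenyl gives an at least 2.4-fold higher number from compound 2 to compound 3 (0.39 log units; beyond the scatter) and an at least 3.5-fold higher number from compound 1 to compound 3 (0.55 log units; beyond the scatter), whereas the only earlier step stayed within the scatter. Activity at this position therefore depends on which substituted phenyl is attached.

The compounds shown cannot tell whether the fluorine atom itself or its place on the ring drives this step. From the compounds shown here alone, how an unsubstituted phenyl, or a phenyl carrying a methoxy group or an amine, would behave here also remains open.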